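The compounds below may be only part of what the source reports. "The series", "measured", "known", "first", "only" and "open" are said of these compounds alone.

Measured so far: compound 1 `O=C1NCCN1c1ccc(S(=O)(=O)Nc2ccc(F)c(F)c2)cc1` with 620 nM, compound 2 `COc1cccc(NS(=O)(=O)c2ccc(N3CCNC3=O)cc2)c1` with 120 nM, and compound 3 `Cc1cccc(NS(=O)(=O)c2ccc(N3CCNC3=O)cc2)c1` with 190 nM, all in a functional assay on MCF7 cells (Homo sapiens) for antiproliferative activity, read by sulforhodamine B assay, with a stated time of 48 h; a lower number here means a stronger inhibitor, a higher number a weaker inhibitor.

Among these three numbers compound 3 stands second highest. Its nearest neighbour is compound 2, and the gap a 1.6-fold higher number from compound 2 to compound 3 (0.20 log units; within the scatter) lies within the scatter, so the two cannot be ordered. Its furthest neighbour is compound 1, and that step, a 3.3-fold lower number from compound 1 to compound 3 (0.51 log units; beyond the scatter), is beyond the scatter.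

The unmeasured compound 4 `O=C1NCCN1c1ccc(S(=O)(=O)Nc2ccc(F)cc2)cc1` differs from compound 3 in one place: 4-fluorophenyl in place of 3-methylphenyl on a sulfonamide nitrogen.

For the measured compounds named here, two measured steps bear on this change, since both replace a fluorinated phenyl with a differently substituted one on the sulfonamide nitrogen. a 5.2-fold lower number from compound 1 to compound 2 (0.71 log units; beyond the scatter) and a 3.3-fold lower number from compound 1 to compound 3 (0.51 log units; beyond the scatter) both lowered the number when the fluorines left. Compound 4 brings one fluorine back, though not the same pattern as compound 1, so the move from compound 3 is expected to run the other way, toward a higher number, but likely by less than the full step from compound 1 to compound 3, since only one fluorine enters.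

Compound 4 is therefore expected to give about 380 nM in this assay, with a range of 170 nM to 850 nM, an estimated step of a 2.0-fold higher number from compound 3 to compound 4 (0.30 log units; within the scatter) from compound 3.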

Compound 4, half-maximal inhibitory concentration: 690 nM
For compound 4 the middle estimate is 1.8-fold (0.26 log units) below the measured one; the measured number falls inside the stated range.
By their numbers in this assay, from the lowest: compounds 2 and 3 (each within the scatter of the next); then compounds 1 and 4 (each within the scatter of the next).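

In this assay the change from 3-methylphenyl to 4-fluorophenyl on the sulfonamide nitrogen gives a 3.6-fold higher number from compound 3 to compound 4 (0.56 log units; beyond the scatter) and so is about as large as the step that separated compound 1 from compound 3, while the change from 3-methoxyphenyl gives a 5.8-fold higher number from compound 2 to compound 4 (0.76 log units; beyond the scatter) in the same direction. For the compounds shown here, the single fluorine of compound 4 thus goes with the full number of the difluorinated compound, for a 1.1-fold higher number from compound 1 to compound 4 (0.05 log units; within the scatter) shows that removing one fluoro group leaves no readable difference at this position. Across these compounds the substituted phenyl groups therefore fall into two pairs, with the fluorinated compound 1 and compound 4 giving higher numbers than the methyl and methoxy compound 3 and compound 2, and no compound here goes against this split, though nothing in the data accounts for it.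

As far as these compounds go, what stays open is whether the split follows the identity of the group or where it sits on the ring, a question that a 3-fluorophenyl or a 4-methoxyphenyl on the same nitrogen would address. From the compounds shown here alone, how an unsubstituted phenyl or a 3-aminophenyl would compare with either pair also remains unknown.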